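Shortening the Amine Substituent from Cyclopropyl to Methyl

The source may hold more compounds than are shown below. What is called first, only, known or untested is meant among the compounds shown, and "the series" means these compounds.

Measured so far in a functional assay on HCT-15 cells (Homo sapiens) for inhibition, read by MTT assay, with a stated time of 72 h; on this read-out higher numbers stand for weaker inhibition and lower numbers for stronger inhibition:
compound 1, `COc1cc(Oc2cccc(Nc3ccccc3)c2)cc(OC)c1CNCc1ccc(Br)cc1`, gives 5410 nM
compound 2, `COc1cc(Oc2cccc(Nc3ccccc3)c2)cc(OC)c1CNCc1ccc(Cl)cc1`, gives 4850 nM
compound 3, `COc1cc(Oc2cccc(Nc3ccccc3)c2)cc(OC)c1CNC1CC1`, gives 6140 nM

Compound 3 has the highest of the three numbers, but its neighbours sit close: the steps of a 1.1-fold higher number from compound 1 to compound 3 (0.05 log units; within the scatter) and a 1.3-fold higher number from compound 2 to compound 3 (0.10 log units; within the scatter) are both within the scatter, as is a 1.1-fold lower number from compound 1 to compound 2 (0.05 log units; within the scatter), so the three compounds cannot be separated on these numbers.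

Compound 4, `CNCc1c(OC)cc(Oc2cccc(Nc3ccccc3)c2)cc1OC`, has not been measured. The difference from compound 3 is methyl in place of cyclopropyl on an amine nitrogen. Within the data shown here, the steps that bear on this change are those at the same amine nitrogen, a 1.1-fold higher number from compound 1 to compound 3 (0.05 log units; within the scatter) and a 1.3-fold higher number from compound 2 to compound 3 (0.10 log units; within the scatter), where the group on the amine was swapped between a 4-bromobenzyl, a 4-chlorobenzyl and a cyclopropyl with no movement beyond the scatter. On that basis the number for compound 4 is expected to stay near that of compound 3, with no step beyond the scatter in either direction, and the expected step is a 1.1-fold higher number from compound 3 to compound 4 (0.02 log units; within the scatter). Compound 4 is therefore estimated at 6500 nM, within a range from 3000 nM to 14000 nM.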

Compound 4, half-maximal inhibitory concentration: 8930 nM
Compound 4: the middle estimate sits 1.4-fold (0.14 log units) below what was measured; the measured number falls inside the stated range.
By their numbers in this assay, from the lowest: compounds 2, 1, 3 and 4 (each within the scatter of the next).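

In this assay, cutting the group on the amine nitrogen down to methyl leaves the number within the scatter, with a 1.5-fold higher number from compound 3 to compound 4 (0.16 log units; within the scatter). The same holds against the two benzyl compounds, with a 1.8-fold higher number from compound 2 to compound 4 (0.27 log units; within the scatter) and a 1.7-fold higher number from compound 1 to compound 4 (0.22 log units; within the scatter), so 4-bromobenzyl, 4-chlorobenzyl, cyclopropyl and methyl on this nitrogen cannot be separated, and a single carbon there serves as well as the larger groups on these numbers. Nothing available accounts for this flat result.

The compounds shown leave open whether a group of another kind on this nitrogen, such as a carboxylic acid or a longer chain ending in an amine, or simply the primary amine, would move the number beyond the scatter. They also leave open whether any change on the shared core would do so.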